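The source may hold more compounds than are shown below. What is called first, only, known or untested is meant among the compounds shown, and "the series" means these compounds.

Measured so far in an assay on HEK293 cells for agonist activity at transient receptor potential cation channel subfamily M member 8 (Homo sapiens), read by fluorescence and calcium flux, with a stated time of 15 min; on this read-out lower numbers stand for an effect already at smaller amounts and higher numbers for an effect only at larger amounts of compound:
compound 1 `Cc1ccc(OCC(=O)N(Cc2cccs2)C2CC2)cc1` gives 8 nM
compound 2 `CCN(Cc1cc[nH]c1)C(=O)COc1ccc(C)cc1` gives 21800 nM

Compound 1 stands lowest of the two numbers; compound 2 lies far above it, beyond the scatter, and the two structures differ in more than one place, so nothing further is read from that pair. Compound 3 `Cc1ccc(OCC(=O)N(Cc2cccs2)C(C)(C)C)cc1` keeps the core of compound 1 and differs in one place: tert-butyl in place of cyclopropyl on an amide-type nitrogen. Going by the values given here, no step of this kind has been measured. A step of modest size, toward a somewhat higher number, is expected: a 1.9-fold higher number from compound 1 to compound 3 (0.27 log units; within the scatter). Compound 3 is estimated at 15 nM, within a range from 4 nM to 60 nM.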

Compound 3, half-maximal effective concentration: 11000 nM
Beside the measured number, compound 3's estimate is 730-fold (2.87 log units) below it, outside the stated range (above it).
By their numbers in this assay, from the lowest: compound 1; then compounds 3 and 2 (each within the scatter of the next).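

In this assay the group on the amide-type nitrogen is not interchangeable: with the rest of the core of compound 1 unchanged, tert-butyl in place of cyclopropyl gives a 1400-fold higher number from compound 1 to compound 3 (3.14 log units; beyond the scatter) and removes the three-membered ring. This one position alone can therefore carry a step of this size. No measurement at hand accounts for the step.

The compounds shown do not separate the loss of the ring from the branching of tert-butyl. Isopropyl or cyclobutyl on this nitrogen would bear on that question.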